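Swapping the ring substituent on a sulfonyl-bearing compound

The compounds below may be only part of what the source reports. "The series", "measured", "known", "first", "only" and "open" are said of these compounds alone.

Measured so far:
compound 1, `COc1ccc(Cn2c(N)nc3c2c(=O)n(CC2CC2)c(=O)n3CC2CC2)cc1`: 60%
compound 2, `Nc1nc2c(c(=O)n(CC3CC3)c(=O)n2CC2CC2)n1S(=O)(=O)c1ccc(C(F)(F)F)cc1`: 0%
compound 3, `Nc1nc2c(c(=O)n(CC3CC3)c(=O)n2CC2CC2)n1S(=O)(=O)c1ccc(Cl)cc1`: 1%

Of the compounds shown here, three sharing one core have been tested in an assay on isolated protein with dual specificity calcium/calmodulin-dependent 3',5'-cyclic nucleotide phosphodiesterase 1B (Bos taurus) as the target, tested at 100 uM; on this read-out higher numbers stand for more inhibition at the one concentration tested (going by the name of the read-out) and lower numbers for less inhibition. Compound 1 gives 60%, whereas compound 2 gives 0% and compound 3 gives 1%. Compound 3 thus holds the second highest of the three numbers: its nearest neighbour is compound 2, within the scatter, and its furthest is compound 1, well beyond it. The step of a number 59 percentage points lower from compound 1 to compound 3 (beyond the scatter) shows how much is lost when the 4-methoxybenzyl on the aromatic nitrogen is replaced by a (4-chlorophenyl)sulfonyl.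

Compound 4, `Cc1ccc(S(=O)(=O)n2c(N)nc3c2c(=O)n(CC2CC2)c(=O)n3CC2CC2)cc1`, keeps that sulfonyl and differs from compound 3 only in this way: methyl in place of chloro on an aromatic carbon

The step that bears most directly on this change is a number 1 percentage points higher from compound 2 to compound 3 (within the scatter), where a different group at the same place on the same ring made no difference beyond the scatter. Both sulfonyl-bearing compounds sit near zero, so no step beyond the scatter is expected for a number 1 percentage points higher from compound 3 to compound 4 (within the scatter). Compound 4 is therefore estimated at 2%, with a range from -5% to 12%.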

Compound 4, a percentage reported as inhibition, at one concentration (the size of the read-out at that concentration, not a potency): 9%
Estimate against measurement, compound 4: 7 percentage points below; low and high end bracket the measured number.
By their numbers in this assay, from the lowest: compounds 2, 3 and 4 (each within the scatter of the next); then compound 1.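

In this assay, three different groups have now stood on the same aromatic carbon, para to a large group, on the ring of the sulfonyl: trifluoromethyl, chloro and methyl. Swapping in the methyl gives a number 8 percentage points higher from compound 3 to compound 4 (within the scatter) and a number 9 percentage points higher from compound 2 to compound 4 (within the scatter), so none of the three can yet be told apart from the others at this place. The large gap to the benzyl compound also persists with this third ring group, at a number 51 percentage points lower from compound 1 to compound 4 (beyond the scatter), and nothing measured here offers an explanation for either finding.

From the compounds shown here alone, whether any group on this ring carbon can lift the number remains open, and an amine, a carboxylic acid or a nitrile there would test that. Also open, going by these compounds, is whether the loss belongs to the sulfonyl link or to the ring group, since compound 1 differs from compound 4 in both, and a 4-methylbenzyl on the aromatic nitrogen would help separate the two.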